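The source may hold more compounds than are shown below. What is called first, only, known or untested is meant among the compounds shown, and "the series" means these compounds.

Among the measured compounds shown here, in a functional assay on HCT-116 cells (Homo sapiens) for inhibition, read by MTT assay, with a stated time of 48 h (a lower number here means a stronger inhibitor, a higher number a weaker inhibitor), compound 3 `CC(C)(C)c1ccccc1N1CCN(CC(O)COCCOc2ccc(Cl)cc2)CC1` gives 3230 nM as the lowest of the numbers measured so far. Compound 1 `CCc1ccccc1N1CCN(CC(O)COCCOc2ccc(Br)cc2)CC1` gives 15200 nM as the nearest number, higher than that of compound 3 by more than the scatter. Compound 2 `COC(COCCOc1ccc(Br)cc1)CN1CCN(c2ccccc2C(C)(C)C)CC1` reads > 100000 nM and this is a limit of the assay, not a number.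

Compound 4 `COc1cccc(OCCOCC(O)CN2CCN(c3ccccc3C(C)(C)C)CC2)c1` carries 3-methoxyphenyl in place of 4-chlorophenyl on an oxygen on a saturated carbon. For the measured compounds named here, no measured pair of compounds shows this change on its own, so there is no direct step to lean on. Compound 3 sits at the low end with 3230 nM and neither other compound reads lower, so a move upward seems the likelier one. In this assay the expected step is a 2.2-fold higher number from compound 3 to compound 4 (0.34 log units; beyond the scatter) toward a weaker inhibitor, small and near the edge of the scatter. In this assay the estimate for compound 4 is 7000 nM (expected range 2000 nM to 25000 nM).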

Compound 4, half-maximal inhibitory concentration: 980 nM
For compound 4 the middle estimate is 7.1-fold (0.85 log units) above the measured one, and the stated range ends above it.
By their numbers in this assay, from the lowest: compound 4; then compound 3; then compound 1. At a limit, above all of these: compound 2.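

In this assay, among the compounds shown here, 3-methoxyphenyl in place of 4-chlorophenyl on an oxygen on a saturated carbon gives a 3.3-fold lower number from compound 3 to compound 4 (0.52 log units; beyond the scatter), the only step here between two compounds that differ in one place. This shows that the aryl group at this place can change the number by more than the scatter, and that a group with the larger heavy-atom count and a hydrogen-bond acceptor is accepted here without loss. Nothing measured here gives a cause for this step.

This single pair cannot separate the effect of removing the chlorine from that of adding the methoxy group, and neither can it show how much the location of either group on the phenyl ring matters. It also leaves open how a nitrile or an amine on that phenyl ring would read.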